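Fluoro in place of methoxy: expecting little change

The source may hold more compounds than are shown below. What is called first, only, known or untested is meant among the compounds shown, and "the series" means these compounds.

Compound 1 `N=C(N)c1ccc(-c2ccc(-c3cc(Cl)cc(Cl)c3)s2)s1` gives 1740 nM in a functional assay on UO-31 cells (Homo sapiens) for inhibition, read by sulforhodamine B assay, with a stated time of 48 h; a lower number here means a stronger inhibitor of growth, a higher number a weaker inhibitor of growth.
Compound 2 `COc1ccc(-c2ccc(-c3ccc(C(=N)N)o3)o2)cc1` gives 1720 nM in this assay.
Compound 3 `N=C(N)c1ccc(-c2ccc(-c3cncc4ccccc34)s2)s1` gives 1390 nM in this assay.

The three measured compounds sit close together in this assay. Compound 2 gives a number that lies near both of the others: its gap to compound 1 and its gap to compound 3 are each within the usual scatter of repeated measurements, so no order among the three can be read from these numbers. Among the compounds with values here, no two of the measured compounds differ in only one place, so there is no measured step to lean on.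

Compound 4 `N=C(N)c1ccc(-c2ccc(-c3ccc(F)cc3)o2)o1` is the unmeasured partner of compound 2. The change is fluoro in place of methoxy on an aromatic carbon. Within the data shown here, with no measured step of this kind available and all three measured compounds lying within scatter of one another, no shift beyond the scatter is expected in either direction. The step of a 1.0-fold higher number from compound 2 to compound 4 (0.02 log units; within the scatter) is estimated to be small. Compound 4 is expected to give about 1800 nM, with a range from 700 nM to 4500 nM.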

Compound 4, concentration for 50% growth inhibition: 1430 nM
Estimate against measurement, compound 4: 1.3-fold (0.10 log units) above, within the range that was stated.
By their numbers in this assay, from the lowest: compounds 3, 4, 2 and 1 (each within the scatter of the next).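

Within the data shown here, this pair gives the first step that can be read at a single place: in this assay, fluoro in place of methoxy gives a 1.2-fold lower number from compound 2 to compound 4 (0.08 log units; within the scatter) and nothing more. At this position, on a six-membered aromatic ring of carbon only and para to a large group, the two groups therefore cannot be told apart by this read-out, although fluoro has one heavy atom and no hydrogen-bond acceptor where methoxy has two heavy atoms and one acceptor. Nothing measured here offers an explanation for this result.

From the compounds shown here alone, with only these two groups compared at this position, it remains open whether an amine, a carboxylic acid or a longer chain such as butoxy would also stay within the scatter. Going by these compounds, whether the same change would give a similar step on another core, such as that of compound 1, is also open.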